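A few compounds are considered here, and "the series" means these few. Any claim that something is new, unique, unknown or untested is made for them only; others in the source may bear on it.

Working notes on the series. Compound 1 `CCN(CC)S(=O)(=O)c1ccc(S(=O)(=O)N2CCC[C@@H](C(=O)N[C@@H]3CCN(C(=O)OC(C)(C)C)C3)C2)cc1` in a functional assay on MIA PaCa-2 cells (Homo sapiens) for inhibition, read by MTT assay, with a stated time of 7 days (a lower number here means a stronger inhibitor, a higher number a weaker inhibitor), gives 200 nM. Among the measured compounds shown here, compound 2 `CCN(CC)S(=O)(=O)c1ccc(S(=O)(=O)N2CCC[C@@H](C(=O)NC3CN(C(=O)C4CC4)C3)C2)cc1` in this assay gives 2800 nM, the second highest of the three numbers to hand; its nearest neighbour is compound 3 `CCOC(=O)[C@@H]1CCCN(S(=N)(=O)c2ccc(S(=O)(=O)N(CC)CC)cc2)C1`, for which this assay returns 12100 nM, and the step of a 14-fold higher number from compound 1 to compound 2 (1.15 log units; beyond the scatter) is the only single-site change measured so far. Compound 4 `CCN(CC)S(=O)(=O)c1ccc(S(=O)(=O)N2CCC[C@@H](C(=O)N3CCN(c4nc(C)no4)CC3)C2)cc1` is next to be run. Its change from compound 2 is 4-(3-methyl-1,2,4-oxadiazol-5-yl)piperazin-1-yl in place of (1-(cyclopropylcarbonyl)azetidin-3-yl)amino on a carbonyl carbon. For the measured compounds named here, no measured step bears directly on this replacement; compound 3 carries a different group on the shared core and its comparison with compound 2 is not a single-site one. Going by the values given here, the only guidance is the step of a 14-fold higher number from compound 1 to compound 2 (1.15 log units; beyond the scatter), which shows that the group attached to this carbonyl carbon can shift the number by a large amount. Compound 1 with 200 nM shows that a bulkier carbamate-bearing ring at this position sits far lower than compound 2. On that basis compound 4 is estimated at 1500 nM, with a range from 300 nM to 8000 nM. The expected step is a 1.9-fold lower number from compound 2 to compound 4 (0.27 log units; within the scatter), modest and uncertain given the absence of a matched precedent.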

Compound 4, half-maximal inhibitory concentration: 250 nM
The estimate for compound 4 lay 6.0-fold (0.78 log units) above the measured number; the measured number lies below the stated range.
By their numbers in this assay, from the lowest: compounds 1 and 4 (each within the scatter of the next); then compound 2; then compound 3.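

In this assay the step of an 11-fold lower number from compound 2 to compound 4 (1.05 log units; beyond the scatter) shows that a low number at this carbonyl carbon does not depend on the amide hydrogen, which compound 1 and compound 2 both carry and compound 4 lacks. Compound 1 at 200 nM and compound 4 at 250 nM stand within the scatter of each other, so a low number here is reached by two different groups, and the tert-butoxycarbonyl carbamate of compound 1 is not required for it. Nothing at hand gives a cause for the step.

The change alters the ring, the amide nitrogen and the end group all at once, so the compounds shown leave open how much of the step belongs to the piperazine and how much to the 3-methyl-1,2,4-oxadiazol-5-yl group. A piperazine amide ending in a free secondary amine or an acetyl group, set on the shared core, would bear on that question, as would a homopiperazine ring carrying the same oxadiazole.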